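The source may hold more compounds than are shown below. What is called first, only, known or untested is meant among the compounds shown, and "the series" means these compounds.

In a functional assay on HCT-116 cells (Homo sapiens) for cytotoxicity, read by scintillation counting and thymidine incorporation, with a stated time of 72 h (on this read-out lower numbers stand for stronger inhibition and higher numbers for weaker inhibition), compound 1 `CCOc1cc(C(=CC#N)c2ccc(S(C)(=O)=O)cc2)ccc1OC` is reported only as a limit, > 10000 nM; (the limit of > 10000 nM in this assay, at which 1 of the 3 values shown sits). Compound 2 `COc1cc(OC)cc(/C(=C/C#N)c2ccc(OC)c(OC)c2)c1` gives 110 nM in this assay, the higher of the two numbers shown, and compound 3 `COc1ccc(C(=CC#N)c2cc(OC)c(OC)c(OC)c2)cc1N` gives 1.8 nM, the lower one. Compound 4 `COc1cc(OC)cc(C(=CC#N)c2ccc(OC)c(OC)c2)c1` is not yet measured in this assay. Between compound 2 and compound 4 the structures differ only in drawn geometry: the two compounds have the same atoms and bonds; at least one stereo element is drawn with a configuration in one of them and without one in the other: 1 of 1 stereo elements differ; a double bond is drawn E in compound 2 and without a configuration in compound 4. Since the atoms and bonds are identical, no step beyond the scatter is expected in this assay in either direction; the expected step of a 1.4-fold higher number from compound 2 to compound 4 (0.13 log units; within the scatter) reflects only the uncertainty of an undefined double-bond geometry. Compound 4 is therefore estimated at 150 nM, within 60 nM to 400 nM, in this assay.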

Compound 4, half-maximal inhibitory concentration: 18 nM
Compound 4: the middle estimate sits 8.3-fold (0.92 log units) above what was measured; measured number below the stated range.
By their numbers in this assay, from the lowest: compound 3; then compound 4; then compound 2. At a limit, above all of these: compound 1.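

In this assay the series shows a 6.1-fold lower number from compound 2 to compound 4 (0.79 log units; beyond the scatter), with no atom or bond changed. Drawn geometry at the double bond bearing the nitrile therefore cannot be set aside in this series, and compound 2 and compound 4 cannot be treated as one entry. The only difference available to account for the gap is this: the fact that one of compounds 2 and 4 is drawn with a defined configuration and the other without, at the place where they differ

Open, going by these compounds, is what the undefined material of compound 4 contains and which geometry goes with the lower number. Also open, on these data alone, is how a carboxylic acid in place of the nitrile would read at this double bond.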